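The compounds below may be only part of what the source reports. "The series", "measured", "known", "first", "only" and "open" are said of these compounds alone.

Measured in a functional assay on MCF7 cells (Homo sapiens) for cytotoxicity, read by MTT assay, with a stated time of 72 h; on this read-out lower numbers stand for stronger inhibition and higher numbers for weaker inhibition:
compound 1 `CCN(CC)C(=O)NCC/C(=C(\c1ccccc1)c1ccc(OC)cc1)c1ccccc1`, a limit of the assay, > 50000 nM
compound 2 `COc1ccc(/C(=C(/CCNC(=O)C(=O)NC2CCCCC2)c2ccccc2)c2ccccc2)cc1`, 12100 nM

Among the compounds with values here, compound 2 holds the only number in this assay; the other value shown is a limit. The step to it, cyclohexylcarbamoyl in place of diethylamino on a carbonyl carbon, gave an at least 4.1-fold lower number from compound 1 to compound 2 (0.61 log units; beyond the scatter), its size resting on the limit of the limit of > 50000 nM in this assay, at which 1 of the 2 values shown sits. Compound 3 `COc1ccc(/C(=C(/CCNC(=O)C(=O)N2CCCC2)c2ccccc2)c2ccccc2)cc1` carries pyrrolidin-1-yl in place of cyclohexylamino on a carbonyl carbon. Within the data shown here, the single measured step bears on this only loosely: from compound 1 to compound 2 an amide hydrogen entered and the number fell, while the change from compound 2 to compound 3 takes that amide hydrogen away again and exchanges the six-membered ring for a smaller one. The expected step is therefore a modest rise in number, a 2.1-fold higher number from compound 2 to compound 3 (0.32 log units; beyond the scatter). Compound 3 is estimated at 25000 nM, within 8000 nM to 80000 nM, with a real chance that only a limit is reported.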

Compound 3, half-maximal inhibitory concentration: > 50000 nM
Compound 3: only a limit was reported; the forecaster's own chance of this, stated with the estimate: 35%; at least 2.0-fold (0.30 log units) between middle value and limit.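

Within this assay, the group on this carbonyl carbon matters more than compound 2 alone could show: pyrrolidin-1-yl in place of cyclohexylamino gave an at least 4.1-fold higher number from compound 2 to compound 3 (0.61 log units; beyond the scatter). For compound 3 the value is a limit, > 50000 nM. The second carbonyl present in compound 2 and compound 3 is therefore not enough on its own to bring a number within range, and the step from compound 1 to compound 3 cannot be read, as both values are limits: the limit of > 50000 nM in this assay, at which 2 of the 3 values shown sit.

The change from compound 2 to compound 3 removes the amide hydrogen and alters the ring together, so the data do not tell which of the two carries the step. A cyclopentylamino or a piperidin-1-yl group on the same carbonyl carbon would separate these two changes.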